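A few compounds are considered here, and "the series" means these few. Any claim that something is new, unique, unknown or untested is made for them only; others in the source may bear on it.

Compound 3 `CC(=O)c1cccc(-c2cccc(OC(=O)NC3CCCCC3)c2)c1` gives 9.1 nM in an assay on cell membranes for binding affinity to Fatty-acid amide hydrolase 1 (Rattus norvegicus) (on this read-out lower numbers stand for stronger inhibition and higher numbers for weaker inhibition), the lowest number among the three measured compounds. Its nearest neighbour is compound 1 `O=C(NC1CCCCC1)Oc1cccc(-c2cccc(F)c2)c1`, which in this assay gives 96.6 nM; the step of an 11-fold lower number from compound 1 to compound 3 (1.03 log units; beyond the scatter). Furthest away is compound 2 `O=C(NC1CCCCC1)Oc1cccc(-c2cccc(Cc3ccccc3)c2)c1`, which gives 1860 nM, so that a 200-fold lower number from compound 2 to compound 3 (2.31 log units; beyond the scatter); between these two, a 19-fold higher number from compound 1 to compound 2 (1.28 log units; beyond the scatter). All three steps change only the group on the aromatic carbon, and each is large.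

Compound 4 `O=C(NC1CCCCC1)Oc1cccc(-c2cccc(CO)c2)c1` takes the step (hydroxymethyl in place of acetyl on an aromatic carbon). Among the measured compounds shown here, no measured step carries a hydroxymethyl, so the expectation rests on the three steps above: every change at this carbon moved the number by a large amount, and acetyl gave the lowest number, so a higher number than compound 3 is expected. Compound 4 is therefore estimated at 60 nM, within 12 nM to 300 nM, an expected step of a 6.6-fold higher number from compound 3 to compound 4 (0.82 log units; beyond the scatter).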

Compound 4, half-maximal inhibitory concentration: 8.67 nM
For compound 4 the middle estimate is 6.9-fold (0.84 log units) above the measured one, and the stated range ends above it.
By their numbers in this assay, from the lowest: compounds 4 and 3 (each within the scatter of the next); then compound 1; then compound 2.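

In this assay, hydroxymethyl and acetyl cannot be told apart at this aromatic carbon (a 1.0-fold lower number from compound 3 to compound 4 (0.02 log units; within the scatter)), even though a hydrogen-bond donor enters and the double bond outside aromatic rings leaves. The carbonyl of acetyl is therefore not required for a low number in this set, and hydroxymethyl also stands well clear of fluoro (an 11-fold lower number from compound 1 to compound 4 (1.05 log units; beyond the scatter)) and of the benzyl compound (a 210-fold lower number from compound 2 to compound 4 (2.33 log units; beyond the scatter)). Nothing available accounts for the two groups reading alike. Still open, from the compounds shown here alone, is whether an amine, a carboxylic acid or a longer chain such as hydroxyethyl at this carbon stays at this level. A methoxymethyl group would show whether the hydroxy hydrogen matters.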